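The source may hold more compounds than are shown below. What is called first, only, known or untested is meant among the compounds shown, and "the series" means these compounds.

Series notes. Compound 1 `Cc1ccc(S/C(=C/c2c[nH]c3ccccc23)C(=O)c2ccc(Br)cc2)cc1` gives 10000 nM in a functional assay on DU-145 cells (Homo sapiens) for inhibition, read by trypan blue exclusion, with a stated time of 96 h; a lower number here means a stronger inhibitor of growth, a higher number a weaker inhibitor of growth. Compound 2 `Cc1ccc(S/C(=C/c2ccc(N(C)C)cc2)C(=O)c2ccc(Br)cc2)cc1` reaches only a limit of this assay, > 100000 nM. Compound 3 `COc1ccc(/C=C(/Sc2ccc(C)cc2)C(=O)c2ccc(Br)cc2)cc1` gives 50000 nM in this assay, the highest of the two plain numbers, its nearest measured neighbour standing at a 5.0-fold higher number from compound 1 to compound 3 (0.70 log units; beyond the scatter). The step to compound 4 `Cc1ccc(S/C(=C/c2ccc(F)c(C)c2)C(=O)c2ccc(Br)cc2)cc1` is 4-fluoro-3-methylphenyl in place of 4-methoxyphenyl on a double-bonded chain carbon bound to a double-bonded chain carbon. Among the measured compounds shown here, no measured step exchanges this ring for another carbon-only ring without an acceptor; the steps touching the same place are a 5.0-fold higher number from compound 1 to compound 3 (0.70 log units; beyond the scatter), modest, and an at least 2.0-fold lower number from compound 2 to compound 3 (0.30 log units; that floor lies within the scatter), whose floor lies within the scatter. No step beyond the scatter is therefore expected, no change at the digits printed from compound 3 to compound 4 (within the scatter). Compound 4 is estimated at 50000 nM, expected between 15000 nM and 150000 nM.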

Compound 4, concentration for 50% growth inhibition: 25000 nM
Beside the measured number, compound 4's estimate is 2.0-fold (0.30 log units) above it, within the range that was stated.
By their numbers in this assay, from the lowest: compound 1; then compounds 4 and 3 (each within the scatter of the next). At a limit, above all of these: compound 2.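

Taking the hydrogen-bond acceptor out of this ring leaves the reading in this assay within the scatter, a 2.0-fold lower number from compound 3 to compound 4 (0.30 log units; within the scatter), so the 4-methoxyphenyl acceptor is not needed to hold this level. The 1H-indol-3-yl group still stands apart from the carbon-only ring, a 2.5-fold higher number from compound 1 to compound 4 (0.40 log units; beyond the scatter). The step away from 4-(dimethylamino)phenyl is an at least 4.0-fold lower number from compound 2 to compound 4 (0.60 log units; beyond the scatter), and it rests on a limit: the limit of > 100000 nM in this assay, at which 1 of the 4 values shown sits.

Still open, going by these compounds, is how a carboxylic acid or a morpholine on this ring would read. Also open, on these data alone, is whether any ring other than 1H-indol-3-yl reaches the level of compound 1.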